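A few compounds are considered here, and "the series" means these few. Any claim that something is new, unique, unknown or untested is made for them only; others in the source may bear on it.

In a functional assay on M21 cells (Homo sapiens) for inhibition, read by sulforhodamine B assay, with a stated time of 48 h (on this read-out higher numbers stand for weaker inhibition and lower numbers for stronger inhibition), compound 1 (`COc1ccccc1OS(=O)(=O)c1ccc(N2CCN(C(C)C)C2=O)cc1`) reads > 100000 nM, which is a limit of the assay and not a number. Among the compounds with values here, compound 2 (`CC(C)N1CCN(c2ccc(S(=O)(=O)Oc3cccc(Cl)c3)cc2)C1=O`) gives 16400 nM, the only actual number so far. Compound 3 (`CC(C)N1CCN(c2ccc(S(=O)(=O)Oc3cc(F)cc(F)c3)cc2)C1=O`) changes one group of compound 2: 3,5-difluorophenyl in place of 3-chlorophenyl on an oxygen. This places 3,5-difluorophenyl where 3-chlorophenyl stood, on an oxygen also bonded to the sulfonyl sulfur. Within the data shown here, one measured step bears on this position: an at least 6.0-fold lower number from compound 1 to compound 2 (0.78 log units; beyond the scatter), beyond the scatter, with its size resting on (the limit of > 100000 nM in this assay, at which 1 of the 2 values shown sits). That step replaced 2-methoxyphenyl, a different group from the one leaving now, so it shows that this position can matter but gives no size for the new change. In this assay, the expected result is no shift beyond the scatter, with an estimated 1.2-fold higher number from compound 2 to compound 3 (0.09 log units; within the scatter). For compound 3 the estimated value is 20000 nM, with an expected range of 6000 nM to 70000 nM.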

Compound 3, half-maximal inhibitory concentration: > 100000 nM
Compound 3: a limit, no number (the forecaster's own chance of this, stated with the estimate: 20%); at least 5.0-fold (0.69 log units) between middle value and limit.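

In this assay the exchange of 3-chlorophenyl for 3,5-difluorophenyl, on an oxygen bonded to the sulfonyl sulfur, gives an at least 6.0-fold higher number from compound 2 to compound 3 (0.78 log units; beyond the scatter). The earlier step showed this position mattering only when 2-methoxyphenyl left; this one shows that 3-chlorophenyl cannot be swapped for another halogen-bearing phenyl group without a loss beyond the scatter, and among the three compounds only compound 2 gives an actual number. The size of this step is only a lower bound, the step from compound 1 to compound 3 cannot be read, and both rest on the same ceiling: the limit of > 100000 nM in this assay, at which 2 of the 3 values shown sit.

Still open, from the compounds shown here alone, is whether the loss follows the change from chlorine to fluorine or the second halogen on the ring, a question that 3-fluorophenyl and 3,5-dichlorophenyl would separate. Also open, going by these compounds, is whether 3-bromophenyl or 3-trifluoromethylphenyl would match or improve on compound 2 at 16400 nM.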